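The source may hold more compounds than are shown below. What is called first, only, known or untested is meant among the compounds shown, and "the series" means these compounds.

Compound 1 `Cc1cccc(C(=O)N(C(=S)OCCN2C(=O)c3ccccc3C2=O)c2ccc(Cl)cc2)c1` in an ADME assay on MT4 cells (Homo sapiens) for cytotoxicity, read by MTT assay (a higher number here means that more compound is tolerated, a lower number that less compound is tolerated), gives 58000 nM. Among the numbers obtained, compound 1 sits at the top, but compound 3 `O=C1c2ccccc2C(=O)N1CCOC(=S)N(C(=O)c1ccc(Cl)c(Cl)c1)c1ccccc1` gives 52000 nM, a gap within the scatter, so the two are not separable. Compound 2 `Cc1ccc(N(C(=O)c2cccc(C)c2)C(=S)OCCN2C(=O)c3ccccc3C2=O)cc1` is recorded only as a limit of the assay, > 100000 nM. The step of an at least 1.7-fold higher number from compound 1 to compound 2 (0.23 log units; that floor lies within the scatter) is set by the limit of > 100000 nM in this assay, at which 1 of the 3 values shown sits, and so cannot be sized beyond its floor.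

Compound 4 `O=C1c2ccccc2C(=O)N1CCOC(=S)N(C(=O)c1cccc(Cl)c1Cl)c1ccc(Cl)cc1` carries the change (2,3-dichlorophenyl in place of 3-methylphenyl on a carbonyl carbon). Going by the values given here, no measured step touches this position directly; compound 3 differs from compound 1 in two places, and its value only shows that a dichlorophenyl carbonyl is compatible with a tolerance close to that of compound 1. The step to compound 2 runs chloro to methyl with an increase that may be small; the present change runs methyl to chlorines and is therefore expected to give, if anything, a slightly lower number. Compound 4 is estimated at 45000 nM, between 20000 nM and 100000 nM, an expected step of a 1.3-fold lower number from compound 1 to compound 4 (0.11 log units; within the scatter).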

Compound 4, half-maximal cytotoxic concentration: 54000 nM
Compound 4: the middle estimate sits 1.2-fold (0.08 log units) below what was measured; the measured number falls inside the stated range.
By their numbers in this assay, from the lowest: compounds 3, 4 and 1 (each within the scatter of the next). At a limit, above all of these: compound 2.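

Going by these compounds alone, at the carbonyl carbon, 2,3-dichlorophenyl in place of 3-methylphenyl gives the first direct reading at this position in this assay, with a 1.1-fold lower number from compound 1 to compound 4 (0.03 log units; within the scatter). With the rest of compound 1 held constant, this position therefore takes the exchange of the methyl for two chlorines without a change that can be separated from the scatter. Nothing recorded for the series bears on why the two groups read alike.

As far as these compounds go, it remains open whether a group of another kind on this carbonyl carbon, such as a phenyl bearing an amine or a carboxylic acid, or a longer alkyl chain, would read the same way. Also open, from the compounds shown here alone, is how far the series extends upward, since compound 2 is recorded only as a limit, > 100000 nM.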